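The compounds below may be only part of what the source reports. "The series", "measured", "known", "first", "only" and "open" are said of these compounds alone.

Measured so far in a functional assay on HepG2 cells (Homo sapiens), read by MTT assay, with a stated time of 72 h; a higher number here means a weaker inhibitor, a lower number a stronger inhibitor:

Compound 1, `Cc1ccc(C(=O)Oc2ccc(Br)cc2C(=O)Nc2ccc(C(F)(F)F)cc2)cc1`, gives 26800 nM.
Compound 2, `Cc1ccc(C(=O)Oc2ccc(Cl)cc2C(=O)Nc2ccc(C(F)(F)F)cc2)cc1`, gives 6900 nM.

Compound 2 holds the lower of the two numbers. For the measured compounds named here, the one measured step, a 3.9-fold lower number from compound 1 to compound 2 (0.59 log units; beyond the scatter), exchanged a halogen on the shared core and lies beyond the scatter.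

Compound 3, `Cc1ccc(C(=O)Oc2ccc(Cl)cc2C(=O)Nc2ccc(Cl)c(Cl)c2)cc1`, has not yet been measured. It differs from compound 2 in one place: 3,4-dichlorophenyl in place of 4-(trifluoromethyl)phenyl on an amide-type nitrogen. The measured step does not bear on this change, since it concerned a halogen on the core rather than the group on the amide-type nitrogen, so nothing measured here tells how the number will move. Without a guide, the expectation for compound 3 is a step of a 1.1-fold lower number from compound 2 to compound 3 (0.03 log units; within the scatter), that is, no change beyond the scatter. Compound 3 is therefore estimated at 6500 nM, within a range from 2000 nM to 22000 nM.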

Compound 3, half-maximal inhibitory concentration: 2550 nM
Beside the measured number, compound 3's estimate is 2.5-fold (0.41 log units) above it; the range from low to high includes it.
By their numbers in this assay, from the lowest: compound 3; then compound 2; then compound 1.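

In this assay, 3,4-dichlorophenyl in place of 4-(trifluoromethyl)phenyl on the amide-type nitrogen gives a 2.7-fold lower number from compound 2 to compound 3 (0.43 log units; beyond the scatter) and so marks a stronger inhibitor. This shows that the group on the amide-type nitrogen can also move the number, whereas the earlier step showed this only for a halogen on the shared core. Nothing available here explains why this exchange lowers the number.

The compounds shown leave open whether both chlorines are needed for this step or whether a single chlorine on the phenyl ring would do the same. As far as these compounds go, it also remains open how the number would respond to a different kind of group on that ring, such as an amine or a carboxylic acid.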